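The compounds below may be only part of what the source reports. "The series", "measured", "known", "first", "only" and "open" are said of these compounds alone.

Working notes on the series. In a functional assay on VSMC cells (Rattus norvegicus) (on this read-out lower numbers stand for stronger inhibition and higher numbers for weaker inhibition), compound 1 (`Cc1c(O)c(C)c2c(c1O)C(=O)CC(c1cccc(O)c1)O2`) is reported as "not active" (no number reported) and so has no single number. Compound 2 (`COc1ccccc1C1CC(=O)c2c(O)c(C)c(O)c(C)c2O1`) is likewise reported as "not active" (no number reported) with no number given. Compound 3 (`COc1cc(O)ccc1C1CC(=O)c2c(O)c(C)c(O)c(C)c2O1`) gives > 100000 nM as a limit of the assay and not a number. Compound 1 therefore stands in a group of three with no measured potency, and no order can be drawn among them.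

The step to compound 4 (`Cc1c(O)c(C)c2c(c1O)C(=O)CC(c1ccco1)O2`) places furan-2-yl in place of 3-hydroxyphenyl on a saturated ring carbon, next to the ring oxygen (furan-2-yl in place of 3-hydroxyphenyl on a saturated ring carbon). Within the data shown here, no measured pair in this assay sizes a change of this kind. The expectation rests on compound 1 ("not active" (no number reported)) and is for no step beyond the scatter, with a report of no activity as the likeliest result. For compound 4 the estimated value is 100000 nM with an expected range from 20000 nM to 300000 nM on this read-out.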

Compound 4, half-maximal inhibitory concentration: 6700 nM
Beside the measured number, compound 4's estimate is 15-fold (1.17 log units) above it; the measured number lies below the stated range.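

In this assay, among these compounds, compound 1 is reported as "not active" (no number reported) and so no step to compound 4 can be read from it. The compounds shown leave open the size of the change from 3-hydroxyphenyl to furan-2-yl, and nothing given accounts for the activity of compound 4.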